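Fluoro for nitro: cytotoxicity notes on the series

The source may report more compounds than this note shows. Statements on the series, on what has been measured and on what is new or still open speak of the compounds shown alone.

Values in a toxicity assay on NIH3T3 cells (Mus musculus) for cytotoxicity, read by resazurin assay (a lower number here means that less compound is needed, a higher number that more compound is needed for the effect), are as follows
- compound 1 (`COC(=O)c1ccc(NCc2cncn2Cc2cccc([N+](=O)[O-])c2)cc1-c1ccccc1`): > 10000 nM (limit)
- compound 2 (`O=C(c1ccc(NCc2cncn2Cc2ccc(-c3ccccc3)cc2)cc1-c1ccccc1)N1CCCCC1`): > 1000 nM (limit)
- compound 3 (`N#Cc1ccc(NCc2cncn2Cc2ccc(-c3ccccc3)cc2N)cc1-c1ccccc1`): > 1000 nM (limit)

Compound 1 stands at > 10000 nM as a limit, not a number. Within the data shown here, no value is an exact number, and no step between measured compounds is available. Compound 4 (`COC(=O)c1ccc(NCc2cncn2Cc2cccc(F)c2)cc1-c1ccccc1`) carries fluoro in place of the nitro of compound 1, on an aromatic carbon, meta to a large group (fluoro in place of nitro on an aromatic carbon). No change beyond the scatter is expected in this assay and the estimated step is (a number no higher from compound 1 to compound 4 (the limit leaves the size open)). For compound 4 the expected value is 10000 nM with an estimated range of 3000 nM to 30000 nM and a report as a limit is likely.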

Compound 4, half-maximal effective concentration: > 1000 nM
Compound 4: only a limit was reported; the forecaster's own chance of this, stated with the estimate: 75%; the middle value lies beyond the limit too.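

Compound 1 and compound 4 both stand as limits only, and the step between them cannot be read. Going by these compounds, whether fluoro in place of nitro shifts the concentration needed in this assay stays open.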